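The source may hold more compounds than are shown below. What is called first, only, known or untested is meant among the compounds shown, and "the series" means these compounds.

Four related compounds are compared here, all built on the same shared core. Compound 1 `COc1cc(NC(C)CCCNC(=O)Nc2cccc(F)c2)c2ncccc2c1` carries a 3-fluorophenyl group on an amide-type nitrogen. In a functional assay on HeLa cells (Homo sapiens) for inhibition, read by MTT assay, with a stated time of 72 h (a lower number here means a stronger inhibitor, a higher number a weaker inhibitor), compound 1 gives 18000 nM. Compound 2 `COc1cc(NC(C)CCCNC(=O)NNC(=O)Nc2cccc(F)c2)c2ncccc2c1` differs from compound 1 by ((3-fluorophenyl)carbamoyl)amino in place of 3-fluorophenyl on an amide-type nitrogen. In this assay compound 2 gives only > 250000 nM, which is a limit of the assay and not a number. The step of an at least 13-fold higher number from compound 1 to compound 2 (1.14 log units; beyond the scatter) therefore rests on that limit, at which one of the three values sits (the limit of > 250000 nM in this assay, at which 1 of the 3 values shown sits). Compound 3 `COc1cc(NC(C)CCCNC(=O)Nc2cccc(C(F)(F)F)c2)c2ncccc2c1` differs from compound 1 by trifluoromethyl in place of fluoro on an aromatic carbon. In this assay compound 3 gives 14000 nM, so that the step of a 1.3-fold lower number from compound 1 to compound 3 (0.11 log units; within the scatter). Going from compound 2 to compound 3 the change in this assay is an at least 17-fold lower number from compound 2 to compound 3 (1.25 log units; beyond the scatter).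

Compound 4 `COc1cc(NC(C)CCCNC(=O)NNC(=O)Nc2cccc(C(F)(F)F)c2)c2ncccc2c1` has not yet been measured. It differs from compound 2 by trifluoromethyl in place of fluoro on an aromatic carbon, the same change that separates compound 1 from compound 3, and made at the same place. The two cores on which this change is made differ by ((3-fluorophenyl)carbamoyl)amino in place of 3-fluorophenyl on an amide-type nitrogen. Because the step of a 1.3-fold lower number from compound 1 to compound 3 (0.11 log units; within the scatter) was small, the step from compound 2 to compound 4 is expected to be similarly small, a step that the limit leaves unreadable from compound 2 to compound 4. Since compound 2 sits at the limit (the limit of > 250000 nM in this assay, at which 1 of the 3 values shown sits), compound 4 is expected to remain there too, with an estimated value of 300000 nM in this assay, between 150000 nM and 800000 nM.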

Compound 4, half-maximal inhibitory concentration: 4900 nM
Compound 4: the middle estimate sits 61-fold (1.79 log units) above what was measured; measured number outside the range, below it.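

Replacing fluoro with trifluoromethyl on the aromatic ring did not behave the same way on the two cores in this assay, where the new step is an at least 51-fold lower number from compound 2 to compound 4 (1.70 log units; beyond the scatter), and the two steps stand well apart: the same change on two cores in this assay, a 1.3-fold lower number (0.11 log units; within the scatter) from compound 1 to compound 3 and an at least 51-fold lower number (1.70 log units; beyond the scatter) from compound 2 to compound 4, at least 39-fold (1.59 log units) apart, beyond the scatter of two such steps. In this series, a small step on the core of compound 1 therefore gave no safe guide to the size of the same step on the core of compound 2, although the size of the new step is not known exactly, since compound 2 gives > 250000 nM, which is a limit of the assay and not a number: the limit of > 250000 nM in this assay, at which 1 of the 4 values shown sits. These two pairs show that the outcome of this change can depend on the core, but they do not show why it does, and two pairs give no general rule for other cores.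

The compounds shown leave open whether other groups in the same place on the aromatic ring, such as chloro, methoxy or a nitrile, would also give a large step on the core of compound 2 and a small one on the core of compound 1. They also leave open whether a longer chain in the shared core would keep this difference between the two cores.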